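A few compounds are considered here, and "the series" means these few. Any claim that something is new, unique, unknown or untested is made for them only; others in the source may bear on it.

Compound 3 `CCCc1nc(-c2ccccc2)c(CNCCN2CCN(c3ccc(OC)cc3)CC2)o1` gives 51.5% in an assay on HEK293 cells for inhibition of Voltage-dependent T-type calcium channel subunit alpha-1G (Homo sapiens), read by fluorescence, tested at 10 uM; on this read-out higher numbers stand for more inhibition at the one concentration tested (going by the name of the read-out) and lower numbers for less inhibition. Within the scatter it is indistinguishable from compound 1 `CCCc1nc(-c2ccccc2)c(CNCCN2CCN(c3ccccc3C)CC2)o1` at 51.3% and from compound 2 `CCCc1nc(-c2ccccc2)c(CNCCN2CCN(c3ccccc3C(F)(F)F)CC2)o1` at 54.6%. Compound 4 `CCCc1nc(-c2ccccc2)c(CNCCN2CCN(c3cccc(F)c3)CC2)o1` differs from compound 3 in one place: 3-fluorophenyl in place of 4-methoxyphenyl on an amine nitrogen in a ring. Among the compounds with values here, two measured steps bear directly on this change, both swaps of the aryl group on the same ring nitrogen: a number 0.2 percentage points higher from compound 1 to compound 3 (within the scatter) and a number 3.1 percentage points lower from compound 2 to compound 3 (within the scatter). The third step, a number 3.3 percentage points higher from compound 1 to compound 2 (within the scatter), alters the aryl group in the same region and is likewise flat. No step beyond the scatter is therefore expected in this assay. Compound 4 is expected to give about 52%, with a range from 40% to 64%. This estimate means a step of a number 0.5 percentage points higher from compound 3 to compound 4 (within the scatter), expected to stay within the scatter.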

Compound 4, a percentage reported as inhibition, at one concentration (the size of the read-out at that concentration, not a potency): 62.3%
Compound 4: the middle estimate sits 10.3 percentage points below what was measured; low and high end bracket the measured number.
By their numbers in this assay, from the lowest: compounds 1, 3, 2 and 4 (each within the scatter of the next, the first and the last beyond it).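

Within the data shown here, the aryl group on the ring nitrogen is not silent in this assay, as 3-fluorophenyl gives the first steps beyond the scatter, both modest (a number 10.8 percentage points higher from compound 3 to compound 4 (beyond the scatter); a number 11 percentage points higher from compound 1 to compound 4 (beyond the scatter)). The separation is incomplete, since the step from 2-(trifluoromethyl)phenyl stays within the scatter (a number 7.7 percentage points higher from compound 2 to compound 4 (within the scatter)). No measurement on hand accounts for these steps.

Still open, from the compounds shown here alone, is whether the gain follows the fluorine itself or its place on the aryl ring. Neither 4-fluorophenyl, 3-chlorophenyl nor unsubstituted phenyl appears among the compounds shown.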